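The source may report more compounds than this note shows. Statements on the series, on what has been measured and on what is new or still open speak of the compounds shown alone.

Compounds measured in an ADME assay on J774 cells (Mus musculus) for cytotoxicity; on this read-out lower numbers stand for an effect already at smaller amounts and higher numbers for an effect only at larger amounts of compound:

compound 1 `CCCCC#Cc1c(C)[nH]c2ccc(OC)cc2c1=O` gives only a limit, > 36800 nM.
compound 2 `CCCCC#Cc1c(C)[nH]c2ccc(Cl)cc2c1=O` gives only a limit, > 36300 nM.
compound 3 `COc1cccc2c(=O)c(Cc3ccccc3)c(C)[nH]c12` gives only a limit, > 35800 nM.

All three values sit at limits of this assay: the limit of > 35800 nM in this assay, at which 1 of the 3 values shown sits, the limit of > 36300 nM in this assay, at which 1 of the 3 values shown sits, and (the limit of > 36800 nM in this assay, at which 1 of the 3 values shown sits). Within the data shown here, the one change made within the measured set is chloro in place of methoxy on an aromatic carbon, and its step, a step that the two limits leave unreadable from compound 1 to compound 2, cannot be read in size because both ends are limits.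

Compound 4 `Cc1[nH]c2c(Cl)cccc2c(=O)c1Cc1ccccc1` has not yet been measured. The difference between the core of compound 3 and the core of compound 1 is not broken down here. Compound 4 arises from compound 3 by chloro in place of methoxy on an aromatic carbon; this is the same kind of change as that from compound 1 to compound 2, though the place differs, being ortho to a fused ring and meta to a fused ring rather than meta to a fused ring and para to a fused ring.

In this assay the step from compound 3 to compound 4 is expected to be a step that the limit leaves unreadable from compound 3 to compound 4, resting on the limit of compound 3, > 35800 nM, and on the unreadable step already seen. Compound 4 is therefore estimated at 40000 nM, between 18000 nM and 90000 nM.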

Compound 4, half-maximal effective concentration: > 35200 nM
Compound 4 was reported as a limit; the forecaster's own chance of this, stated with the estimate: 85%; the middle value lies beyond the limit too.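

In this assay compound 4 gives only a limit, > 35200 nM. Compound 3 also stands at a limit, so no step can be read between compound 3 and compound 4. The compounds shown leave open at what concentration any of the four reaches its half-maximal effect, and whether chloro in place of methoxy changes it.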